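This account rests on a few compounds, and the source may have more. Where it says the series, first, only, none or still open, it means among the compounds named here.

Measured compounds:
compound 1, `CCOC(=O)[C@@]1(C(=O)Nc2ccccc2Cl)C[C@H]1c1cc(OC)c(OC)c(OC)c1`: 14400 nM
compound 2, `COc1cc([C@H]2C[C@@]2(CO)C(=O)Nc2ccccc2)cc(OC)c1OC`: > 100000 nM

Both were run in a functional assay on HeLa cells (Homo sapiens) for cytotoxicity, read by MTT assay, with a stated time of 48 h; a lower number here means a stronger inhibitor, a higher number a weaker inhibitor. Compound 1 gives 14400 nM there. For compound 2 the result is a limit of the assay rather than a number: compound 2 gives > 100000 nM in this assay. That reading sits at the limit of > 100000 nM in this assay, at which 1 of the 2 values shown sits, so the true standing of compound 2 is known only as lying at that limit. For the measured compounds named here, no step between compound 1 and compound 2 is traced here; their two values show only that compound 1 returned a number while compound 2 did not.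

Compound 3, `COc1cc([C@H]2C[C@@]2(CO)C(=O)NCc2ccc(C)cc2)cc(OC)c1OC`, is the untested partner of compound 2. It differs in one place: 4-methylbenzyl in place of phenyl on an amide-type nitrogen. The rest of the molecule stays as in compound 2.

With compound 2 at the limit, any step can be judged from one side only. The change in this assay from compound 2 to compound 3 is expected to be small, an at least 1.2-fold lower number from compound 2 to compound 3 (0.09 log units; that floor lies within the scatter), with no clear direction beyond the scatter. Compound 3 is accordingly expected to give about 80000 nM in this assay, with a likely range from 20000 nM to 300000 nM.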

Compound 3, half-maximal inhibitory concentration: > 100000 nM
Compound 3 gave a limit, no number (the forecaster's own chance of this, stated with the estimate: 60%); middle value at least 1.2-fold (0.09 log units) from the limit.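

In this assay compound 3 gives > 100000 nM, a limit of the assay and not a number. For the compounds shown here, compound 2 stands at a limit as well, so no step between compound 2 and compound 3 can be read: the limit of > 100000 nM in this assay, at which 2 of the 3 values shown sit. The compounds shown leave open whether 4-methylbenzyl in place of phenyl on the amide-type nitrogen changes the value at all.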